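This account rests on a few compounds, and the source may have more. Where it says the series, first, only, none or still open, it means among the compounds named here.

Measured so far in a functional assay on HL-60 cells (Homo sapiens) for antiproliferative activity, read by MTT assay, with a stated time of 48 h; a lower number here means a stronger inhibitor, a higher number a weaker inhibitor:
- compound 1 (`CC(=O)OC/C1=C/C[C@](C)(CCC=C(C)C)/C=C/[C@@H](OC(=O)C=C(C)C)[C@](C)(O)/C=C/C1=O`) gives 2950 nM
- compound 2 (`CC(=O)OC/C1=C/C[C@](C)(CCC=C(C)C)/C=C/[C@@H](OC(=O)C=C(C)C)[C@](C)(OC(C)=O)/C=C/C1=O`) gives 3480 nM
- compound 3 (`CC(=O)O[C@]1(C)/C=C/C(=O)/C(CO)=C\C[C@](C)(CCC=C(C)C)/C=C/[C@H]1OC(=O)C=C(C)C`) gives 2370 nM

All three values lie within the usual scatter of one another, so compound 1 stands level with compound 2 and compound 3. Compound 4 (`CC(C)=CCC[C@]1(C)/C=C/[C@@H](OC(=O)C=C(C)C)[C@](C)(O)/C=C/C(=O)/C(CCl)=C\C1`) keeps the core of compound 1 with one change (chloro in place of acetoxy on a saturated chain carbon bound to a double-bonded ring carbon): chloro in place of acetoxy on a saturated chain carbon bound to a double-bonded ring carbon. Among the compounds with values here, two measured steps bear on it. One (a 1.5-fold lower number from compound 2 to compound 3 (0.17 log units; within the scatter)) removes the acetyl from this same acetoxy group, and the other (a 1.2-fold higher number from compound 1 to compound 2 (0.07 log units; within the scatter)) acetylates a different oxygen. Within the data shown here, both stayed small, but no measured compound carries chloro, so the range stays wide. No shift beyond the scatter is expected in this assay for now. The expected change is small (a 1.3-fold lower number from compound 1 to compound 4 (0.13 log units; within the scatter)). For compound 4 the estimate is 2200 nM with an expected range from 700 nM to 6000 nM in this measurement.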

Compound 4, half-maximal inhibitory concentration: 160 nM
Compound 4: the middle estimate sits 14-fold (1.14 log units) above what was measured; measured number outside the range, below it.
By their numbers in this assay, from the lowest: compound 4; then compounds 3, 1 and 2 (each within the scatter of the next).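

In this assay, putting chloro in place of acetoxy on this saturated chain carbon gives an 18-fold lower number from compound 1 to compound 4 (1.27 log units; beyond the scatter), so this position can change the reading strongly. Removing only the acetyl at the same place, a 1.5-fold lower number from compound 2 to compound 3 (0.17 log units; within the scatter), had not shown this. No measurement here explains the large step. The compounds shown leave open whether a bromo group, an amine or a longer chain at this place would give a step of similar size, and whether chloro does the same when the other oxygen carries an acetyl.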